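This account rests on a few compounds, and the source may have more. Where it says the series, first, only, none or still open, it means among the compounds named here.

Compound 1 `CC(=O)SCCC(CCCCC(=O)Nc1ccccc1Cl)SC(C)=O` and compound 2 `CC(=O)SCCC(CCCCC(=O)Nc1cccc(Cl)c1)SC(C)=O` share one core and differ only in the change (3-chlorophenyl in place of 2-chlorophenyl on an amide-type nitrogen). In a functional assay on HO8910 cells (Homo sapiens) for inhibition, read by MTT assay, with a stated time of 24 h, tested at 0.1 ug/mL (on this read-out lower numbers stand for less inhibition of growth and higher numbers for more inhibition of growth at the one concentration tested), compound 1 gives 2.48%, and in this assay compound 2 gives 0.27%; the step of a number 2.2 percentage points lower from compound 1 to compound 2 (within the scatter) is small. Compound 3 `O=C(CCCCC(CCSC(=O)c1ccccc1)SC(=O)c1ccccc1)Nc1ccccc1Cl` has a different core, and the difference between the two cores is not broken down here. In this assay compound 3 was reported as "not active" (no number reported), with no single number. Compound 4 `O=C(CCCCC(CCSC(=O)c1ccccc1)SC(=O)c1ccccc1)Nc1cccc(Cl)c1` stands to compound 3 as compound 2 stands to compound 1, through the same kind of change, (3-chlorophenyl in place of 2-chlorophenyl on an amide-type nitrogen). Since the earlier step from compound 1 to compound 2 stayed small, and compound 3 showed no activity, the corresponding step is expected to be small as well. Compound 4 is therefore estimated to give about 1% in this assay, expected to lie between -5% and 8%.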

Compound 4, percent growth inhibition at one concentration: 9.02%
Beside the measured number, compound 4's estimate is 8 percentage points below it; measured number outside the range, above it.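

Among these compounds, compound 3 was reported without a number, so no step from it to compound 4 can be read. The compounds shown leave open whether 3-chlorophenyl in place of 2-chlorophenyl acts alike on both cores. No evidence at hand bears on this result.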